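Weak growth inhibitors: amine swap on the shared core

The source may report more compounds than this note shows. Statements on the series, on what has been measured and on what is new or still open speak of the compounds shown alone.

Going by the values given here, compound 1 `CC1CC(C)CN(c2nc(Nc3ccc(C#N)c(C(F)(F)F)c3)nc(Oc3ccnc4ccccc34)n2)C1` is the only compound of the pair with a number in a functional assay on DU-145 cells (Homo sapiens) for cytotoxicity, read by sulforhodamine B assay, with a stated time of 48 h; a lower number here means a stronger inhibitor of growth, a higher number a weaker inhibitor of growth: compound 1 gives 68000 nM. Compound 2 `N#Cc1ccc(Nc2nc(Oc3ccnc4ccccc34)nc(N3CCN(C(c4ccccc4)c4ccccc4)CC3)n2)cc1C(F)(F)F` reaches only the edge of the method; in this assay compound 2 gives > 100000 nM, which is a limit and not a number (the limit of > 100000 nM in this assay, at which 1 of the 2 values shown sits). Among the compounds with values here, no step between measured compounds is available, so compound 1 stands as the sole fixed point. Compound 3 `CC(C)N1CCN(c2nc(Nc3ccc(C#N)c(C(F)(F)F)c3)nc(Oc3ccnc4ccccc34)n2)CC1` is not yet measured; it differs from compound 1 in one place: 4-isopropylpiperazin-1-yl in place of 3,5-dimethylpiperidin-1-yl on an aromatic carbon, between two ring nitrogen atoms, meta to the (quinolin-4-yl)oxy group. The two measured values show that neither amine at this position gives a strong inhibitor of growth in this assay. For compound 3 a step of a 1.3-fold higher number from compound 1 to compound 3 (0.10 log units; within the scatter) is expected, not beyond the usual scatter, toward weaker growth inhibition if anything. The estimate for compound 3 in this assay is 85000 nM, expected between 30000 nM and 250000 nM.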

Compound 3, concentration for total growth inhibition: > 100000 nM
Compound 3 ended at the assay's limit; the forecaster's own chance of this, stated with the estimate: 40%; at least 1.1-fold (0.07 log units) between middle value and limit.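

In this assay the replacement gives an at least 1.4-fold higher number from compound 1 to compound 3 (0.16 log units; that floor lies within the scatter), and since that floor lies within the scatter, the change cannot be called a real loss of growth inhibition. Compound 3 gives > 100000 nM, which is a limit of the assay and not a number. At this position, 4-isopropylpiperazin-1-yl joins the amines that give no strong inhibitor of growth, and only compound 1 retains a number: the limit of > 100000 nM in this assay, at which 2 of the 3 values shown sit.

As far as these compounds go, whether morpholine or a dimethylamino group on this aromatic carbon would give a number clearly lower than that of compound 1 remains open. From the compounds shown here alone, the true size of the step to compound 3 also remains open, and no order can be read between compound 2 and compound 3, as both values are limits.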